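Adding a methyl to compound 3

The source may hold more compounds than are shown below. What is called first, only, known or untested is meant among the compounds shown, and "the series" means these compounds.

In an ADME assay on MRC5 cells (Homo sapiens) for inhibition, with a stated time of 72 h (a lower number here means that less compound is needed, a higher number that more compound is needed for the effect), compound 1 (`COc1cccc(OC)c1C(=O)Nc1c[nH]nc1C(=O)N[C@H]1CC[C@H](O)CC1`) gives 34000 nM. Compound 2 (`COc1cccc(OC)c1C(=O)Nc1c[nH]nc1C(=O)NC1CCC1`) reads > 50000 nM, which is a limit. Compound 3 (`COc1cccc(OC)c1C(=O)Nc1c[nH]nc1C(=O)NCc1ccccn1`) reads > 50000 nM, also a limit. The series therefore shows (the limit of > 50000 nM in this assay, at which 2 of the 3 values shown sit).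

Compound 4 (`COc1cccc(OC)c1C(=O)Nc1c[nH]nc1C(=O)NCc1ncccc1C`) has methyl in place of hydrogen on an aromatic carbon, ortho to a large group and two atoms from the ring nitrogen: methyl in place of hydrogen on an aromatic carbon.

The nearest measured changes are on the amide-type nitrogen: an at least 1.4-fold higher number from compound 1 to compound 2 (0.16 log units; that floor lies within the scatter) and an at least 1.4-fold higher number from compound 1 to compound 3 (0.16 log units; that floor lies within the scatter). Neither alters this ring carbon, so no shift beyond the scatter is expected in this assay, and another limit is likely.

The expected change is a step that the limit leaves unreadable from compound 3 to compound 4.

For compound 4 the estimated value is 55000 nM, with an expected range of 25000 nM to 100000 nM.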

Compound 4, half-maximal effective concentration: > 50000 nM
Compound 4: no number, only a limit; the forecaster's own chance of this, stated with the estimate: 70%; the middle value does not contradict the limit.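

With methyl on this aromatic carbon, ortho to a large group and two atoms from the ring nitrogen, the series stays at the same limit in this assay: the limit of > 50000 nM in this assay, at which 3 of the 4 values shown sit.

From the compounds shown here alone, the steps to compound 4 from compound 3 and compound 2 cannot be read, so the size of the methyl change remains unknown. Against the 4-hydroxycyclohexyl group, the reading is an at least 1.4-fold higher number from compound 1 to compound 4 (0.16 log units; that floor lies within the scatter).

Open, going by these compounds, is whether an amine or a carboxylic acid on this ring carbon would give a number rather than a limit. Also open, on these data alone, is whether a longer chain there would do so.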